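Anilide versus acid on a dihydrofuran carboxamide core

The source may report more compounds than this note shows. Statements on the series, on what has been measured and on what is new or still open speak of the compounds shown alone.

Measured compounds:
Compound 1, `C=CC1=C(C(=O)Nc2ccccc2)C(c2ccc(OC)cc2)OC1`, is reported in a functional assay on QGY7701 cells (Homo sapiens) for cytotoxicity, read by MTT assay, with a stated time of 24 h (a lower number here means a stronger inhibitor, a higher number a weaker inhibitor), only as a limit, > 100000 nM.
Compound 2, `C=CC1=C(C(=O)NCc2ccc(C)cc2)C(c2ccc(OC)c(OC)c2)OC1`, gives 69100 nM in this assay.
Compound 3, `C=CC1=C(C(=O)O)C(c2ccc(OC)c(OC)c2)OC1`, is reported in this assay only as a limit, > 100000 nM.

Compound 3 therefore stands at the weak end of what has been measured, at the floor of the assay together with compound 1, as the limit of > 100000 nM in this assay, at which 2 of the 3 values shown sit, shows. Going by the values given here, the only step that bears on it, an at least 1.4-fold higher number from compound 2 to compound 3 (0.16 log units; that floor lies within the scatter), exchanges an amide for the free acid and moves the number upward by an amount whose floor lies within the scatter, so the direction of an amide-for-acid change is at best faintly toward stronger inhibition.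

Compound 4, `C=CC1=C(C(=O)Nc2ccccc2)C(c2ccc(OC)c(OC)c2)OC1`, differs from compound 3 by anilino in place of hydroxy on a carbonyl carbon. Among the compounds with values here, this is the reverse of the kind of change seen in the step from compound 2 to compound 3, but with a different amine, the one carried by compound 1, which itself reaches only the limit. In this assay compound 4 is therefore expected to remain weak, with the step of a number no higher from compound 3 to compound 4 (the limit leaves the size open) estimated as no more than a marginal gain.

Compound 4 is estimated at 100000 nM, within a range of 40000 nM to 300000 nM.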

Compound 4, half-maximal inhibitory concentration: > 100000 nM
Compound 4: a limit, no number (the forecaster's own chance of this, stated with the estimate: 60%); the middle value lies on the limit itself.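

In this assay compound 4 is reported only as a limit, > 100000 nM. Going by these compounds alone, the one new step that can be read is an at least 1.4-fold higher number from compound 2 to compound 4 (0.16 log units; that floor lies within the scatter), with phenyl in place of 4-methylbenzyl on an amide-type nitrogen, so this change gives no separation beyond the scatter. The steps from compound 3 to compound 4 and from compound 1 to compound 4 cannot be read, and with anilino on this carbonyl carbon the dimethoxy-substituted compounds now include a second one without a number, leaving compound 2 as the only one of the four with a measured number: the limit of > 100000 nM in this assay, at which 3 of the 4 values shown sit.

On these data alone, whether a benzyl group without the methyl on the amide-type nitrogen, or a methyl ester on the carbonyl carbon, would give a readable number on the shared core stays open. Within the data shown here, also open is whether 4-methylbenzyl on that nitrogen would still give a number with the single methoxy of compound 1 on the aromatic ring.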